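Removing the bromo group from compound 2

A few compounds are considered here, and "the series" means these few. Any claim that something is new, unique, unknown or untested is made for them only; others in the source may bear on it.

Of the compounds shown here, two have numbers so far. In a functional assay on HCT-116 cells (Homo sapiens) for inhibition, read by MTT assay, with a stated time of 48 h (on this read-out higher numbers stand for weaker inhibition and lower numbers for stronger inhibition), compound 1 `COc1ccc(CNc2cc(OC)c(OC)c(OC)c2)cc1Br` gives 48100 nM, and compound 2 `C/C=C/C(=O)N(Cc1ccc(OC)c(Br)c1)c1cc(OC)c(OC)c(OC)c1` gives 2800 nM, the lower of the two numbers. For the measured compounds named here, the single measured step, a 17-fold lower number from compound 1 to compound 2 (1.23 log units; beyond the scatter), is large and beyond the scatter, but it places (prop-1-en-1-yl)carbonyl in place of hydrogen on a nitrogen. Compound 3 `C/C=C/C(=O)N(Cc1ccc(OC)cc1)c1cc(OC)c(OC)c(OC)c1` keeps that group and differs from compound 2 elsewhere: hydrogen in place of bromo on an aromatic carbon. In words, hydrogen stands in place of bromo on an aromatic carbon, so 3-bromo-4-methoxyphenyl becomes 4-methoxyphenyl. Going by the values given here, no measured pair tests this change, so the one measured step bears on it only indirectly and gives neither its size nor its direction. The expectation stays anchored on compound 2 at 2800 nM, since the nitrogen substituent is unchanged. A modest move toward a higher number in this assay is expected, far smaller than the measured step, and this rests on judgement alone. The expected step is a 2.3-fold higher number from compound 2 to compound 3 (0.37 log units; beyond the scatter). For compound 3 the estimated value is 6500 nM, with an expected range of 1800 nM to 25000 nM.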

Compound 3, half-maximal inhibitory concentration: 500 nM
The estimate for compound 3 lay 13-fold (1.11 log units) above the measured number, outside the stated range (below it).
By their numbers in this assay, from the lowest: compound 3; then compound 2; then compound 1.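

In this assay, taking the bromo group off the aromatic carbon ortho to a methoxy group gives a 5.6-fold lower number from compound 2 to compound 3 (0.75 log units; beyond the scatter) and so does not cost activity in this series: 4-methoxyphenyl is the better of the two groups measured here, not 3-bromo-4-methoxyphenyl. For the compounds shown here, this is the first measured change away from the nitrogen, and it shows that the aromatic position still moves the number once the (prop-1-en-1-yl)carbonyl group is held fixed, so the nitrogen substituent is not the only place that matters. Nothing among the data given explains the direction of this step.

On these data alone, at this position the series offers only a comparison of hydrogen with bromine, so it remains open whether the trend follows atom size, with fluoro or chloro falling between compound 3 and compound 2, or whether a hydroxy or a methyl group would break from both. As far as these compounds go, it is also open whether the gain seen on placing the (prop-1-en-1-yl)carbonyl group on the nitrogen carries over to the 4-methoxyphenyl compounds, where the amine counterpart of compound 3 has no number in hand.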